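Notes on the series: from compound 3 to compound 4

The source may report more compounds than this note shows. Statements on the series, on what has been measured and on what is new or still open speak of the compounds shown alone.

Of the compounds shown here, three have been measured in a functional assay on MDA-MB-231 cells (Homo sapiens) for antiproliferative activity, read by MTT assay; a higher number here means a weaker inhibitor, a lower number a stronger inhibitor. Compound 1 `CCCCCCCCCCCCCCCc1cc(=O)c2c(O)cc(O)c(C)c2o1` gives 6790 nM. Compound 3 `CCCCCCCCCCCCCCCc1cc(=O)c2c(O)c(C)c(O)cc2o1` gives 42800 nM; among the two numbers in this assay compound 3 stands highest, with compound 1 the nearest at a lower number, and that gap lies beyond the scatter. Compound 2 `CCCCCCCCCCCCCCCc1cc(=O)c2c(O)c(C)c(OCOC)c(C)c2o1` reaches only a limit in this assay, > 87000 nM, so no number is known for it (the limit of > 87000 nM in this assay, at which 1 of the 3 values shown sits).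

Compound 4 `CCCCCCCCCCCCCCCc1cc(=O)c2c(O)c(C)c(O)c(C)c2o1` is not yet measured in this assay. Relative to compound 3 it differs by methyl in place of hydrogen on an aromatic carbon. Among the measured compounds shown here, no step between measured compounds is recorded for this kind of change, so the measured set gives no direct read on its size. Compound 1 and compound 3, each carrying one methyl group on the shared core, show numbers that differ beyond the scatter, compound 1 being the lower. For compound 4 the expected step is a 2.1-fold lower number from compound 3 to compound 4 (0.33 log units; beyond the scatter), toward a lower number. Compound 4 is estimated at 20000 nM, with a range from 6000 nM to 70000 nM.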

Compound 4, half-maximal inhibitory concentration: > 87000 nM
Compound 4: only a limit was reported; the forecaster's own chance of this, stated with the estimate: 15%; middle value at least 4.3-fold (0.63 log units) from the limit.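

In this assay, among the compounds shown here, the first readable steps for methyl in place of hydrogen on an aromatic carbon both point to a higher number: an at least 2.0-fold higher number from compound 3 to compound 4 (0.30 log units; that floor lies within the scatter) and an at least 12-fold higher number from compound 1 to compound 4 (1.10 log units; beyond the scatter). The step from compound 1 clears the scatter, so a second methyl on the shared core does not bring the number down there, while the step from compound 3 rests on a floor within the scatter. The step between compound 2 and compound 4 cannot be read, and the other two steps are floors rather than full sizes, since compound 4 gives only a limit: the limit of > 87000 nM in this assay, at which 2 of the 4 values shown sit.

From the compounds shown here alone, how far compound 4 lies past that limit remains open. Also open, going by these compounds, is whether an ethyl or methoxy group at this position, or a shorter chain on the shared core, would bring a measurable number back.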